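Pyridyl isomer swap on the benzylamide arm

The source may hold more compounds than are shown below. What is called first, only, known or untested is meant among the compounds shown, and "the series" means these compounds.

Compound 1 `CN(C)CCN1CCN(C2=Nc3ccccc3C(CC(=O)NCc3ccccc3)N2c2ccc(-c3ccccc3)cc2)CC1` gives 2390 nM in a functional assay on cells (Homo sapiens) for cytotoxicity, read by MTT assay, with a stated time of 48 h; on this read-out lower numbers stand for stronger inhibition and higher numbers for weaker inhibition. Compound 2 `COc1ccc(CNC(=O)CC2c3ccccc3N=C(N3CCN(CCN(C)C)CC3)N2c2ccc(-c3ccccc3)cc2)cc1`, with methoxy in place of hydrogen on an aromatic carbon, gives 3820 nM in this assay; the step of a 1.6-fold higher number from compound 1 to compound 2 (0.20 log units; within the scatter) stays within the scatter. Compound 3 `CN(C)CCN1CCN(C2=Nc3ccccc3C(CC(=O)NCc3ccccn3)N2c2ccc(-c3ccccc3)cc2)CC1` carries pyridin-2-yl in place of phenyl on the saturated chain carbon bound to the amide-type nitrogen. In this assay compound 3 returns only a limit, > 5000 nM, which is the limit of > 5000 nM in this assay, at which 1 of the 3 values shown sits. Its standing is therefore known only one-sidedly: an at least 2.0-fold higher number from compound 1 to compound 3 (0.32 log units; beyond the scatter), whereas an at least 1.3-fold higher number from compound 2 to compound 3 (0.11 log units; that floor lies within the scatter) has a floor that lies within the scatter.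

Compound 4 `CN(C)CCN1CCN(C2=Nc3ccccc3C(CC(=O)NCc3ccncc3)N2c2ccc(-c3ccccc3)cc2)CC1` differs from compound 3 by pyridin-4-yl in place of pyridin-2-yl on a saturated chain carbon bound to an amide-type nitrogen. Among the measured compounds shown here, no measured step moves the ring nitrogen between positions; the steps that bear on the question only show that going from phenyl to pyridin-2-yl cost at least a modest amount, and that the methoxy change did nothing beyond the scatter. Lacking any measured step between the two pyridyl isomers, no step beyond the scatter is expected in this assay, so the estimated step is a step that the limit leaves unreadable from compound 3 to compound 4. Compound 4 is estimated at 6500 nM, with a range from 2500 nM to 16000 nM, and most likely again reported as a limit.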

Compound 4, half-maximal inhibitory concentration: > 5000 nM
Compound 4: a limit, no number (the forecaster's own chance of this, stated with the estimate: 60%); the middle value lies beyond the limit too.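

With pyridin-4-yl in place of phenyl on the saturated chain carbon bound to the amide-type nitrogen, this assay gives an at least 2.0-fold higher number from compound 1 to compound 4 (0.32 log units; beyond the scatter), so the loss seen with pyridin-2-yl is not confined to that one isomer. Against 4-methoxyphenyl the reading is an at least 1.3-fold higher number from compound 2 to compound 4 (0.11 log units; that floor lies within the scatter), which sets no order. The step from pyridin-2-yl to pyridin-4-yl cannot be read, and neither can any size for it, because compound 3 and compound 4 each return a limit and not a number: the limit of > 5000 nM in this assay, at which 2 of the 4 values shown sit.

On these data alone, how far past that limit either pyridyl compound lies remains open. Also open, as far as these compounds go, is whether pyridin-3-yl at this place, or an amine on the phenyl ring of compound 1, would return a number in this assay.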